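Thiourea Series: From a Fluorophenyl to a Dichlorophenyl Arm

The source may report more compounds than this note shows. Statements on the series, on what has been measured and on what is new or still open speak of the compounds shown alone.

Of the compounds shown here, three sharing one core have been measured in a functional assay on PC-3 cells (Homo sapiens) for antiproliferative activity, read by MTT assay; a lower number here means a stronger inhibitor, a higher number a weaker inhibitor. Compound 1 `CNC(=O)c1ccc(Oc2cccc(NC(=S)Nc3ccc(F)cc3)c2)nc1` gives 32700 nM, the highest of the three numbers. Compound 3 `CNC(=O)c1ccc(Oc2cccc(NC(=S)Nc3ccc(F)c(C(F)(F)F)c3)c2)nc1` gives 7950 nM, and compound 2 `CNC(=O)c1ccc(Oc2cccc(NC(=S)Nc3cc(C(F)(F)F)cc(C(F)(F)F)c3)c2)nc1` gives 5860 nM. Going by the values given here, the one single-point step among them, a 4.1-fold lower number from compound 1 to compound 3 (0.61 log units; beyond the scatter), shows that adding a trifluoromethyl to the fluorophenyl arm lowers the number beyond the scatter; compound 2 stands lower still than compound 1, though no single step links the two.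

Compound 4 `CNC(=O)c1ccc(Oc2cccc(NC(=S)Nc3ccc(Cl)cc3Cl)c2)nc1` differs from compound 1 by 2,4-dichlorophenyl in place of 4-fluorophenyl on an amide-type nitrogen. Among the compounds with values here, no measured step covers this exact change, but both measured departures from compound 1 toward a more heavily substituted arm on the thiourea nitrogen have lowered the number in this assay. The step expected from compound 1 to compound 4 is therefore a modest decrease, a 3.3-fold lower number from compound 1 to compound 4 (0.51 log units; beyond the scatter). For compound 4 the expected value is 10000 nM, within a range from 4000 nM to 30000 nM.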

Compound 4, half-maximal inhibitory concentration: 19300 nM
Beside the measured number, compound 4's estimate is 1.9-fold (0.29 log units) below it; measured number inside the range.
By their numbers in this assay, from the lowest: compounds 2 and 3 (each within the scatter of the next); then compounds 4 and 1 (each within the scatter of the next).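

In this assay, 2,4-dichlorophenyl in place of 4-fluorophenyl on the amide-type nitrogen gives a 1.7-fold lower number from compound 1 to compound 4 (0.23 log units; within the scatter) and so cannot be told apart from no change. Adding trifluoromethyl to the same arm gives a 4.1-fold lower number from compound 1 to compound 3 (0.61 log units; beyond the scatter) and lies beyond the scatter, so at this position not every change to a more heavily substituted arm moves the number beyond the scatter, with compound 4 as the case against and compound 3 as the case for. Nothing available explains why the two steps differ in this way.

The compounds shown leave open what an arm carrying a single chlorine would give, and whether either chlorine of compound 4 matters on its own. They also leave open how a methoxy group or an amine on this arm would compare with the halogens.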